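The source may report more compounds than this note shows. Statements on the series, on what has been measured and on what is new or still open speak of the compounds shown alone.

Working notes on the series. Of the compounds shown here, three have numbers so far in a functional assay on HT-29 cells (Homo sapiens) for inhibition, read by sulforhodamine B assay, with a stated time of 72 h; a lower number here means a stronger inhibitor, a higher number a weaker inhibitor. Compound 1 (`CCOc1ccc(C2C(C3CC3)C(=O)N2c2cc(OC)c(OC)c(OC)c2)cc1`) gives 63 nM, compound 2 (`CCOc1ccc(C2C(O)C(=O)N2c2cc(OC)c(OC)c(OC)c2)cc1`) gives 15 nM and compound 3 (`COc1ccc(C2CC(=O)N2c2cc(OC)c(OC)c(OC)c2)cc1`) gives 65 nM. Compound 3 therefore sits level with compound 1 within the scatter, and compound 2 lies beyond the scatter on the stronger side of both.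

Compound 4 (`CCOc1ccc(C2CC(=O)N2c2cc(OC)c(OC)c(OC)c2)cc1`) differs from compound 3 in one place: methyl in place of hydrogen on a saturated chain carbon bound to an oxygen on an aromatic ring. This is methyl in place of hydrogen on a saturated chain carbon bound to an oxygen on an aromatic ring, or methoxy to ethoxy.

Going by the values given here, no measured pair isolates this change. Among the compounds with values here, the only measured step, a 4.2-fold lower number from compound 1 to compound 2 (0.62 log units; beyond the scatter), is hydroxy in place of cyclopropyl on a saturated ring carbon. That is a different place, and both of its compounds already carry ethoxy, so its size does not transfer. Within the data shown here, it shows only that ethoxy compounds can reach values such as that of compound 1 at 63 nM, level with compound 3.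

With no evidence for a direction, no shift beyond the scatter is expected in this assay. The expected step is a 1.1-fold higher number from compound 3 to compound 4 (0.03 log units; within the scatter). For compound 4 the estimated value is 70 nM, with an expected range of 25 nM to 200 nM.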

Compound 4, half-maximal inhibitory concentration: 65 nM
For compound 4 the middle estimate is 1.1-fold (0.03 log units) above the measured one; measured number inside the range.
By their numbers in this assay, from the lowest: compound 2; then compounds 1, 3 and 4 (each within the scatter of the next).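

The methoxy to ethoxy change now stands as a measured pair in this assay, and it gives no change at the digits printed from compound 3 to compound 4 (within the scatter) on the saturated chain carbon bound to an oxygen on an aromatic ring, so this added methyl shows no effect on the number with hydrogen on the saturated ring carbon. Compound 4 also supplies the ethoxy compound with that hydrogen, which makes both ring-carbon groups readable against it: hydrogen in place of hydroxy gives a 4.3-fold higher number from compound 2 to compound 4 (0.64 log units; beyond the scatter), while hydrogen in place of cyclopropyl gives a 1.0-fold higher number from compound 1 to compound 4 (0.01 log units; within the scatter), so within these ethoxy compounds only hydroxy separates from hydrogen beyond the scatter, and cyclopropyl does not. Nothing available accounts for the step seen with hydroxy or for the absence of a step with methyl or cyclopropyl.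

As far as these compounds go, whether the flat result holds for a longer chain on that oxygen, such as propoxy or butoxy, remains open, as does whether it would hold with hydroxy on the saturated ring carbon. Also open, from the compounds shown here alone, is whether an amine or a fluorine on the saturated ring carbon would match hydroxy or stay with hydrogen and cyclopropyl.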